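Cytotoxicity of a Triazine Pair and an Untested Homologue

The source may report more compounds than this note shows. Statements on the series, on what has been measured and on what is new or still open speak of the compounds shown alone.

Measured so far:
Compound 1, `N#Cc1ccc(Nc2nc(N)nc(Oc3ccc(Cl)c4ccccc34)n2)cc1`: 237000 nM
Compound 2, `CCNc1nc(Nc2ccc(C#N)cc2)nc(Oc2ccc3cc(Br)ccc3c2Br)n1`: 74400 nM

In an ADME assay on MT4 cells (Homo sapiens) for cytotoxicity, read by MTT assay, with a stated time of 4 days (a higher number here means that more compound is tolerated, a lower number that less compound is tolerated), compound 2 gives 74400 nM, the lower of the two numbers; compound 1 gives 237000 nM, a gap that lies beyond the scatter. Compound 3, `CCCNc1nc(Nc2ccc(C#N)cc2)nc(Oc2ccc3cc(Br)ccc3c2Br)n1`, has not been measured in this assay. It differs from compound 2 by methyl in place of hydrogen on a saturated chain carbon, two bonds along the chain from a nitrogen on an aromatic ring. Going by the values given here, no measured pair shows this change, so the step from compound 2 to compound 3 is expected to be small, in either direction, and not beyond the scatter: a 1.2-fold lower number from compound 2 to compound 3 (0.09 log units; within the scatter). Compound 3 is therefore estimated at 60000 nM, within 25000 nM to 150000 nM.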

Compound 3, half-maximal cytotoxic concentration: 134000 nM
Compound 3: middle estimate off by 2.2-fold (0.35 log units), on the low side, within the range that was stated.
By their numbers in this assay, from the lowest: compounds 2, 3 and 1 (each within the scatter of the next, the first and the last beyond it).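

Exchanging ethylamino for propylamino gives in this assay a 1.8-fold higher number from compound 2 to compound 3 (0.26 log units; within the scatter), so the added methyl at this position leaves the two compounds within the scatter of each other. Compounds 1 and 2 differ in more than one place and could not show this single step. Nothing at hand gives a reason for this result.

As far as these compounds go, whether a longer chain such as butylamino would stay within the scatter of compound 3 remains open. So does the outcome of a hydroxyl group or a dimethylamino group at the end of the chain.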